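This account rests on a few compounds, and the source may have more. Where it says the series, first, only, none or still open, it means among the compounds named here.

In a functional assay on MKN-45 cells (Homo sapiens) for inhibition, read by MTT assay, with a stated time of 72 h (a lower number here means a stronger inhibitor, a higher number a weaker inhibitor), compound 1 `COc1cc2c(Oc3ccc(NC(=O)c4nn(-c5ccccc5C(F)(F)F)c(=O)cc4C)cc3F)ccnc2cc1OCCCN1CCN(C)CC1` gives 40 nM, and compound 2 `COc1cc2c(Oc3ccc(NC(=O)c4nn(-c5cccc(F)c5)c(=O)cc4C)cc3F)ccnc2cc1OCCCN1CCN(C)CC1` gives 120 nM, the higher of the two numbers; the step of a 3.0-fold higher number from compound 1 to compound 2 (0.48 log units; beyond the scatter) separates them. Compound 3 `COc1cc2c(Oc3ccc(NC(=O)c4nn(-c5ccc(F)c(F)c5)c(=O)cc4C)cc3F)ccnc2cc1OCCCN1CCN(C)CC1` differs from compound 2 by fluoro in place of hydrogen on an aromatic carbon. For the measured compounds named here, no measured step adds a fluoro to an aryl ring; the one step measured, a 3.0-fold higher number from compound 1 to compound 2 (0.48 log units; beyond the scatter), exchanges one whole aryl group for another and bears on this change only loosely. A step in this assay no larger than the scatter is therefore expected for compound 3, namely a 1.2-fold lower number from compound 2 to compound 3 (0.08 log units; within the scatter). Compound 3 is expected to give 100 nM, within a range of 40 nM to 250 nM.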

Compound 3, half-maximal inhibitory concentration: 120 nM
The estimate for compound 3 lay 1.2-fold (0.08 log units) below the measured number; measured number inside the range.
By their numbers in this assay, from the lowest: compound 1; then compounds 2 and 3 (each within the scatter of the next).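

In this assay, fluoro in place of hydrogen on the aromatic carbon ortho to the fluoro group gives no change at the digits printed from compound 2 to compound 3 (within the scatter), so this added fluoro leaves the number unmoved within the scatter. The 3,4-difluorophenyl group remains apart from the 2-(trifluoromethyl)phenyl group, with a 3.0-fold higher number from compound 1 to compound 3 (0.48 log units; beyond the scatter). Nothing measured here speaks to a cause for these numbers. The compounds shown leave open whether a chloro, a methoxy or an amine at this same carbon would move the number. They also leave open whether the lower number of compound 1 follows from its trifluoromethyl group or from that group's place on the ring.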